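Chlorine position on the sulfonyl aryl of compound 3

The compounds below may be only part of what the source reports. "The series", "measured", "known", "first", "only" and "open" are said of these compounds alone.

Measured in an assay on isolated protein for inhibition of cathepsin S (Homo sapiens), read by fluorescence, with stated times of 15 min and 30 min, tested at 5 uM; a higher number here means more inhibition at the concentration tested (going by the name of the read-out), a lower number less inhibition:
compound 1 `O=C(Nc1cccc(/C=C/C(=O)c2nc3ccccc3[nH]2)c1)c1cccc(Cl)c1`: 19.5%
compound 2 `O=C(/C=C/c1cccc(NS(=O)(=O)c2ccccc2Cl)c1)c1nc2ccccc2[nH]1`: 45.7%
compound 3 `O=C(/C=C/c1cccc(NS(=O)(=O)c2cccc(Cl)c2)c1)c1nc2ccccc2[nH]1`: 52.6%

Compound 3 stands at the top of the three numbers, though it is separated from compound 2 by only a number 6.9 percentage points higher from compound 2 to compound 3 (within the scatter), within the scatter; from compound 1 it is separated by a number 33.1 percentage points higher from compound 1 to compound 3 (beyond the scatter), beyond the scatter. The large movements in this set come from exchanging the carbonyl for a sulfonyl on the aryl nitrogen: a number 26.2 percentage points higher from compound 1 to compound 2 (beyond the scatter) and a number 33.1 percentage points higher from compound 1 to compound 3 (beyond the scatter). Moving the chlorine on the sulfonyl aryl, by contrast, gave a number 6.9 percentage points higher from compound 2 to compound 3 (within the scatter), which is inside the scatter.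

Compound 4 `O=C(/C=C/c1cccc(NS(=O)(=O)c2ccc(Cl)cc2)c1)c1nc2ccccc2[nH]1` keeps the sulfonyl and differs from compound 3 only in the chlorine position: 4-chlorophenyl in place of 3-chlorophenyl on a sulfonyl sulfur. Within the data shown here, the one step that bears on this, from compound 2 to compound 3, was a chlorine shift on the same sulfonyl aryl and stayed within the scatter; the steps from compound 1 concern the carbonyl-to-sulfonyl exchange and do not speak to a chlorine shift. In this assay compound 4 is therefore expected to sit close to compound 3, with an estimated step of a number 2.6 percentage points lower from compound 3 to compound 4 (within the scatter), not beyond the scatter. The expected value for compound 4 is 50%, with a range from 30% to 70%.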

Compound 4, a percentage reported as inhibition, at one concentration (the size of the read-out at that concentration, not a potency): 89.4%
Compound 4: middle estimate off by 39.4 percentage points, on the low side; the measured number lies above the stated range.
By their numbers in this assay, from the lowest: compound 1; then compounds 2 and 3 (each within the scatter of the next); then compound 4.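

In this assay the place of the chlorine on the sulfonyl aryl matters far more than the earlier shift suggested: 4-chlorophenyl on the sulfonyl sulfur gives a number 36.8 percentage points higher from compound 3 to compound 4 (beyond the scatter) and a number 43.7 percentage points higher from compound 2 to compound 4 (beyond the scatter), so the series is not indifferent to this change, although the two groups have the same atoms and the same counts of donors and acceptors. The exchange on the aryl nitrogen also reaches much further with this group, with a number 69.9 percentage points higher from compound 1 to compound 4 (beyond the scatter) for (4-chlorophenyl)sulfonyl in place of (3-chlorophenyl)carbonyl. Nothing available explains why the 4-chlorophenyl stands out among the three chlorophenyl isomers.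

Still open, as far as these compounds go, is whether the high number belongs to chlorine itself or would hold with a methoxy group, an amine or a carboxylic acid on the same ring in place of the chlorine. Also open, from the compounds shown here alone, is whether (4-chlorophenyl)carbonyl on the aryl nitrogen would share this gain, or whether it needs the sulfonyl as well.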